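This account rests on a few compounds, and the source may have more. Where it says the series, first, only, none or still open, it means among the compounds named here.

Within the data shown here, in a functional assay on DU-145 cells (Homo sapiens) for inhibition, read by trypan blue exclusion, with a stated time of 96 h (a lower number here means a stronger inhibitor of growth, a higher number a weaker inhibitor of growth), compound 1 `Cc1ccsc1/C=C(/SCc1ccc(Cl)cc1)C(=O)c1ccc(Cl)cc1` gives 50000 nM and compound 2 `Cc1ccc(S/C(=C/c2sccc2C)C(=O)c2ccc(Cl)cc2)cc1` gives 50000 nM so compound 2 stands level with compound 1, the only other compound measured. Compound 3 `Cc1ccsc1/C=C(/SCc1ccccc1F)C(=O)c1ccc(Cl)cc1` has yet to be measured. It carries 2-fluorobenzyl in place of 4-methylphenyl on a sulfur and keeps the rest of the shared core. Among the measured compounds shown here, the one measured step that bears on this change is no change at the digits printed from compound 1 to compound 2 (within the scatter) for 4-methylphenyl in place of 4-chlorobenzyl on a sulfur. For the measured compounds named here, that single step is thin evidence, and no 2-fluorobenzyl compound has a measured value yet. The expected result is no change at the digits printed from compound 2 to compound 3 (within the scatter) and so no shift beyond the scatter in this assay in either direction. For compound 3 the estimated value is 50000 nM with an expected range from 15000 nM to 80000 nM as its likely span.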

Compound 3, concentration for 50% growth inhibition: 50000 nM
Compound 3: the middle estimate sits on the measured number at the digits printed; low and high end bracket the measured number.
By their numbers in this assay, from the lowest: compounds 1, 2 and 3 (each within the scatter of the next).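

In this assay the change from 4-methylphenyl to 2-fluorobenzyl on the sulfur gives no change at the digits printed from compound 2 to compound 3 (within the scatter) and adds a fluorine-bearing group to the picture. Among these compounds, the change of 2-fluorophenyl for 4-chlorophenyl on the saturated chain carbon bound to the sulfur gives no change at the digits printed from compound 1 to compound 3 (within the scatter) as well, so three different groups on this sulfur now read alike, where the earlier compounds offered only one step. No measurement at hand offers an explanation for this level reading.

The compounds shown leave open whether any group on this sulfur can move the number at all, for instance one carrying an amine or a carboxylic acid. They also leave open what a change elsewhere in the shared core would do.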